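Chloro on the anilide ring of a thiophene-amide series

The source may hold more compounds than are shown below. What is called first, only, known or untested is meant among the compounds shown, and "the series" means these compounds.

Measured compounds:
- compound 1, `CCOC(=O)c1c(N)sc(C(=O)Nc2ccccc2)c1-c1ccccc1`, 7490 nM
- compound 2, `CCOC(=O)c1c(NC(=O)CC#N)sc(C(=O)Nc2ccccc2)c1-c1ccccc1`, 630 nM
- compound 3, `N#CCC(=O)Nc1sc(C(=O)Nc2ccccc2)c(-c2ccccc2)c1C#N`, 6590 nM

In a functional assay on HT-29 cells (Homo sapiens) for inhibition, read by MTT assay (on this read-out higher numbers stand for weaker inhibition and lower numbers for stronger inhibition), compound 2 gives the lowest number of the three. The step of a 12-fold lower number from compound 1 to compound 2 (1.08 log units; beyond the scatter) shows how much was gained by adding the (cyanomethyl)carbonyl group, and the step of a 10-fold higher number from compound 2 to compound 3 (1.02 log units; beyond the scatter) shows how much was lost when cyano replaced ethoxycarbonyl. Both steps are large and well beyond the scatter, so compound 2 stands clearly apart from compounds 1 and 3.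

Compound 4, `CCOC(=O)c1c(NC(=O)CC#N)sc(C(=O)Nc2ccc(Cl)cc2)c1-c1ccccc1`, differs from compound 2 in one place: chloro in place of hydrogen on an aromatic carbon. Seen one bond further out, phenylcarbamoyl becomes (4-chlorophenyl)carbamoyl. Neither measured step touches this part of the molecule; both concern groups on the shared core. There is therefore no direct guide for the size or direction of this step, and a change within the scatter is the plainest expectation, giving the estimated step of a 1.3-fold lower number from compound 2 to compound 4 (0.10 log units; within the scatter). Compound 4 is accordingly estimated at 500 nM, with a range from 150 nM to 2000 nM.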

Compound 4, half-maximal inhibitory concentration: 620 nM
Beside the measured number, compound 4's estimate is 1.2-fold (0.09 log units) below it, within the range that was stated.
By their numbers in this assay, from the lowest: compounds 4 and 2 (each within the scatter of the next); then compounds 3 and 1 (each within the scatter of the next).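

In this assay, within the data shown here, the step of a 1.0-fold lower number from compound 2 to compound 4 (0.01 log units; within the scatter) gives the first reading on the phenyl ring of the phenylcarbamoyl group, a part of the molecule that neither earlier step touched. Unlike those two large steps on the shared core, placing chloro para to a large group on this ring leaves compounds 2 and 4 indistinguishable in this assay, so hydrogen and chloro cannot be told apart at this one position. Nothing available here offers an explanation for this result.

From the compounds shown here alone, whether a carboxylic acid, an amine or a methoxy group at the same position would also stay within the scatter remains open. So does whether chloro elsewhere on this ring, or on the nitrile-bearing compound 3, would behave as it does here.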